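Adding one methyl group to compound 1

The source may report more compounds than this note shows. Statements on the series, on what has been measured and on what is new or still open speak of the compounds shown alone.

Values measured in an ADME assay on cells (Macrophage, Mus musculus) for cytotoxicity, read by resazurin assay, with a stated time of 3 days (a higher number here means a weaker inhibitor, a lower number a stronger inhibitor), for three compounds
- compound 1 `O=C(Nc1cccc(C(F)(F)F)c1)c1cc(Cl)ccc1O` gives 5900 nM as a number
- compound 2 `O=C(Nc1cccc(F)c1)c1cc(Cl)ccc1O` gives 15000 nM as a number
- compound 3 `O=C(O)c1cccc(NC(=O)c2cc(Cl)ccc2O)c1` gives > 60000 nM as a limit of the assay

Compound 1 has the lower of the two exact numbers, while compound 3 has only a limit. Compound 4 `Cc1c(NC(=O)c2cc(Cl)ccc2O)cccc1C(F)(F)F` is compound 1 with a single change methyl in place of hydrogen on an aromatic carbon to the structure: methyl in place of hydrogen on an aromatic carbon, ortho to a trifluoromethyl group.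

Among the measured compounds shown here, two measured steps bear on this change only indirectly. Swapping trifluoromethyl for fluoro gave a 2.5-fold higher number from compound 1 to compound 2 (0.41 log units; beyond the scatter) and swapping it for carboxy gave an at least 10-fold higher number from compound 1 to compound 3 (1.00 log units; beyond the scatter) in this series. For the measured compounds named here, compound 4 keeps the trifluoromethyl group, and no measured step adds a methyl. A step beyond the scatter in this assay is therefore not expected, in either direction. The expected step is a 1.2-fold lower number from compound 1 to compound 4 (0.07 log units; within the scatter) and carries real uncertainty. For compound 4 the estimated value is 5000 nM (expected range 2000 nM to 12000 nM).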

Compound 4, half-maximal inhibitory concentration: 8000 nM
Estimate against measurement, compound 4: 1.6-fold (0.20 log units) below, within the range that was stated.
By their numbers in this assay, from the lowest: compounds 1, 4 and 2 (each within the scatter of the next, the first and the last beyond it). At a limit, above all of these: compound 3.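

Within this assay the change of methyl in place of hydrogen on an aromatic carbon, ortho to a trifluoromethyl group, gives a 1.4-fold higher number from compound 1 to compound 4 (0.13 log units; within the scatter) and so adds one carbon without a step beyond the scatter. Among the compounds shown here, the earlier steps all replaced the trifluoromethyl group itself, whereas this one keeps that group and gives the first reading for a change elsewhere on its ring. Nothing measured here accounts for the size of this step.

On these data alone, whether a longer chain such as ethyl, or a group of another kind such as an amine or a carboxylic acid, would be tolerated equally well at this position stays open. Also open, as far as these compounds go, is whether the same methyl would give a similar step on compound 2, which carries fluoro in place of trifluoromethyl.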